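The source may hold more compounds than are shown below. What is called first, only, known or untested is meant among the compounds shown, and "the series" means these compounds.

Measured compounds in an assay for inhibition of serine/threonine-protein kinase 3 (Homo sapiens), read by luminescence and ADP-Glo, in the presence of a further agent that is not named here; a higher number here means a weaker inhibitor, a lower number a stronger inhibitor:
- compound 1 `CCCN(C)c1ncnc2[nH]cc(-c3cccc(Cl)c3)c12` gives 218 nM
- compound 2 `CC(=O)NC1CCN(c2ncnc3[nH]cc(-c4cccc(Cl)c4)c23)CC1` gives 36 nM
- compound 3 `CC1(O)CCN(c2ncnc3[nH]cc(-c4cccc(Cl)c4)c23)CC1` gives 189 nM

Compound 3 stands second highest of the three numbers in this assay. Its nearest neighbour is compound 1, whose number is higher by an amount within the scatter; compound 2 lies furthest away, with a number lower than that of compound 3 by a margin beyond the scatter.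

Compound 4 `Clc1cccc(-c2c[nH]c3ncnc(NCC4CC4)c23)c1` is not yet measured. It differs from compound 3 as follows: (cyclopropylmethyl)amino in place of 4-hydroxy-4-methylpiperidin-1-yl on an aromatic carbon. Among the compounds with values here, the only measured step that bears on this change is a 1.2-fold lower number from compound 1 to compound 3 (0.06 log units; within the scatter), which exchanged one amino substituent for another on the same aromatic carbon and stayed within the scatter. Within the data shown here, compound 2 shows that a substituent at this position can lower the number markedly, but no measured step connects a (cyclopropylmethyl)amino group to the shared core, so the direction of the present change is open. On the basis of the step from compound 1 to compound 3, no step beyond the scatter is expected for a 1.1-fold higher number from compound 3 to compound 4 (0.02 log units; within the scatter). Compound 4 is therefore estimated at 200 nM, with a range from 80 nM to 500 nM.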

Compound 4, half-maximal inhibitory concentration: 213 nM
Beside the measured number, compound 4's estimate is 1.1-fold (0.03 log units) below it, and the stated range covers the measured number.
By their numbers in this assay, from the lowest: compound 2; then compounds 3, 4 and 1 (each within the scatter of the next).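

In this assay, (cyclopropylmethyl)amino in place of 4-hydroxy-4-methylpiperidin-1-yl gives a 1.1-fold higher number from compound 3 to compound 4 (0.05 log units; within the scatter) and so matches a group of 8 heavy atoms with a six-membered ring and an oxygen at this aromatic carbon with a group of 5 heavy atoms with a three-membered carbon ring. Against methyl(propyl)amino, the same group gives a 1.0-fold lower number from compound 1 to compound 4 (0.01 log units; within the scatter) on the same carbon, which makes compound 1, compound 3 and compound 4 a set with no separation, while compound 2 goes against this flat picture with its lower number. Nothing measured alongside these numbers accounts for them.

Open, from the compounds shown here alone, is what sets compound 2 apart from compound 3 at the far end of the piperidine. A free amine or a carboxylic acid at that carbon, or a longer acyl chain on the amide nitrogen, would test how far the lower number extends.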